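Imidazolyl to triazolyl swap on two cores

A few compounds are considered here, and "the series" means these few. Any claim that something is new, unique, unknown or untested is made for them only; others in the source may bear on it.

Compound 1 `Oc1nnc(-n2ccnc2)c2ccccc12` and compound 2 `Oc1nnc(-n2cncn2)c2ccccc12` share one core; in a functional assay (trachea) with Cavia porcellus as the target (on this read-out lower numbers stand for stronger inhibition and higher numbers for weaker inhibition), compound 1 gives 8320 nM and compound 2 gives 16600 nM. The change 1H-1,2,4-triazol-1-yl in place of 1H-imidazol-1-yl on an aromatic carbon produced a 2.0-fold higher number from compound 1 to compound 2 (0.30 log units; within the scatter). Compound 3 `CCn1nc(-n2ccnc2)c2ccccc2c1=O` gives 5370 nM in this assay; the difference between the core of compound 3 and that of compound 1 is not broken down here. Compound 4 `CCn1nc(-n2cncn2)c2ccccc2c1=O` is not yet measured and differs from compound 3 by 1H-1,2,4-triazol-1-yl in place of 1H-imidazol-1-yl on an aromatic carbon. This is the same kind of change as before, not the same: the earlier place was para to a hydroxy group (1 heavy atom), this one is meta to an ethyl group (2 heavy atoms) and para to a group of 1 heavy atom. Within the data shown here, the expected step is a 2.0-fold higher number from compound 3 to compound 4 (0.29 log units; within the scatter), resting on a 2.0-fold higher number from compound 1 to compound 2 (0.30 log units; within the scatter) as the only prior example. Compound 4 is estimated at 10500 nM, between 4500 nM and 25000 nM.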

Compound 4, half-maximal inhibitory concentration: 15800 nM
Beside the measured number, compound 4's estimate is 1.5-fold (0.18 log units) below it; the measured number falls inside the stated range.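

In this assay, 1H-1,2,4-triazol-1-yl in place of 1H-imidazol-1-yl gives a 2.9-fold higher number from compound 3 to compound 4 (0.47 log units; beyond the scatter) and so agrees with the earlier step on the other core: the same change on two cores in this assay, a 2.0-fold higher number (0.30 log units; within the scatter) from compound 1 to compound 2 and a 2.9-fold higher number (0.47 log units; beyond the scatter) from compound 3 to compound 4, 1.5-fold (0.17 log units) apart, within the scatter of two such steps.

The change thus carries across these two cores in the same direction, with sizes that cannot be told apart, though only the newer step lies beyond the scatter. Two cores are a narrow base, and this pair shows nothing about other cores or other read-outs.

Still open, going by these compounds, is whether the step holds with a longer chain such as propyl in place of the ethyl group. Also open, on these data alone, is how an amine or a carboxylic acid on that aromatic carbon compares with either five-membered ring.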